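Triazole aryl variation in a spiro-fused antiproliferative series

The source may report more compounds than this note shows. Statements on the series, on what has been measured and on what is new or still open speak of the compounds shown alone.

Compound 1 `Cc1cccc(-n2nncc2CN2C(=O)C3(C(C#N)=C(N)Oc4c3c3nc5ccccc5nc3c3ccccc43)c3ccccc32)c1` gives 39600 nM in a functional assay on A549 cells (Homo sapiens) for antiproliferative activity, read by MTT assay, with a stated time of 48 h; a higher number here means a weaker inhibitor, a lower number a stronger inhibitor.
Compound 2 `N#CC1=C(N)Oc2c(c3nc4ccccc4nc3c3ccccc23)C12C(=O)N(Cc1cnnn1-c1ccccc1Br)c1ccccc12` gives > 50000 nM in this assay, a limit of the assay.
Compound 3 `COc1ccccc1-n1nncc1CN1C(=O)C2(C(C#N)=C(N)Oc3c2c2nc4ccccc4nc2c2ccccc32)c2ccccc21` gives > 50000 nM in this assay, again a limit of the assay.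

Compound 3 thus stands at the limit of the assay, with no number attached to it, and it shares that position with one other member of the series (the limit of > 50000 nM in this assay, at which 2 of the 3 values shown sit). Only compound 1, carrying 3-methylphenyl on the triazole nitrogen, returns a number, and that number sits close to the limit.

The change under review is 4-acetamidophenyl in place of 2-methoxyphenyl on an aromatic nitrogen, giving compound 4 `CC(=O)Nc1ccc(-n2nncc2CN2C(=O)C3(C(C#N)=C(N)Oc4c3c3nc5ccccc5nc3c3ccccc43)c3ccccc32)cc1`. The measured steps that bear on it are the aryl swaps on the same nitrogen: an at least 1.2-fold higher number from compound 1 to compound 2 (0.10 log units; that floor lies within the scatter) and an at least 1.2-fold higher number from compound 1 to compound 3 (0.10 log units; that floor lies within the scatter). The third, a step that the two limits leave unreadable from compound 2 to compound 3, cannot be read because both ends are limits. All three measured compounds therefore lie at or near the limit, and no aryl group tried so far has moved the series away from it.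

For compound 4 the expectation is a value at or near the limit, with an at least 1.1-fold lower number from compound 3 to compound 4 (0.04 log units; that floor lies within the scatter) estimated as no step beyond the scatter. Compound 4 is estimated at 45000 nM, expected between 15000 nM and 150000 nM, with a real chance that only a limit is reported.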

Compound 4, half-maximal inhibitory concentration: > 50000 nM
Compound 4 gave a limit, no number (the forecaster's own chance of this, stated with the estimate: 60%); at least 1.1-fold (0.04 log units) between middle value and limit.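

Compound 4 places on the aromatic nitrogen the only aryl group shown that carries a hydrogen-bond donor, yet in this assay compound 4 returns only a limit of the assay, > 50000 nM. Among these compounds, the one readable comparison is an at least 1.2-fold higher number from compound 1 to compound 4 (0.10 log units; that floor lies within the scatter); this gives only a floor, the true size stays unknown, and the steps between compounds at the limit cannot be read. With 4-acetamidophenyl added to the 2-bromophenyl and 2-methoxyphenyl groups, the aryl changes shown at this position give no readable separation, and compound 1 is the one exception in returning a number: the limit of > 50000 nM in this assay, at which 3 of the 4 values shown sit.

From the compounds shown here alone, it remains open whether any group on this aryl ring can bring a value clearly inside the measurable range, for example an aminomethyl group, a carboxylic acid or a longer ether chain in place of the acetamido group. Going by these compounds, the true values of the three compounds at the limit also stay unknown, so they cannot be ranked, and the shared core, unchanged in all four compounds, offers no comparison.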